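This account rests on a few compounds, and the source may have more. Where it says the series, first, only, none or still open, it means among the compounds named here.

Measured in a functional assay on HeLa cells (Homo sapiens) for antiproliferative activity, read by MTT assay, with a stated time of 48 h; a higher number here means a weaker inhibitor, a lower number a stronger inhibitor:

- compound 1 `C=C(c1ccc(OC)cc1NC(=O)CO)c1ccc(OC)c2c1OC(C)(C)C=C2`: 40 nM
- compound 2 `C=C(c1ccc(OC)cc1NC(=O)CO)c1ccc(OC)c2c1C=CC(C)(C)O2`: 100 nM
- compound 3 `C=C(c1cc(OC)c(OC)c(OC)c1)c1ccc(OC)cc1NC(=O)CO`: 30 nM

Compound 1, at 40 nM, lies within the scatter of compound 3, which gives 30 nM. Compound 2 shows a higher number, 100 nM, and its gap to compound 1 goes beyond the scatter. Compound 1 therefore sits in the middle of a narrow set of three numbers.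

Compound 4 `C=C(c1ccc(OC)cc1NC(=O)CNCC)c1ccc(OC)c2c1OC(C)(C)C=C2` keeps the core of compound 1 and carries ethylamino in place of hydroxy on a saturated chain carbon bound to a carbonyl carbon. Among the compounds with values here, all three measured compounds carry the hydroxy group, so the data hold no direct precedent for this change, and the uncertainty is wide. A modest step toward a higher number in this assay is expected, possibly none beyond the scatter. The expected step is a 1.5-fold higher number from compound 1 to compound 4 (0.18 log units; within the scatter). For compound 4 the estimated value is 60 nM, with an expected range from 20 nM to 250 nM.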

Compound 4, half-maximal inhibitory concentration: 1090 nM
Estimate against measurement, compound 4: 18-fold (1.26 log units) below; the whole stated range lies below it.
By their numbers in this assay, from the lowest: compounds 3 and 1 (each within the scatter of the next); then compound 2; then compound 4.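

In this assay the replacement of hydroxy by ethylamino on a saturated chain carbon bound to a carbonyl carbon brings a 27-fold higher number from compound 1 to compound 4 (1.44 log units; beyond the scatter) and is a large step. This position, which carries hydroxy in all the earlier compounds, is therefore shown to be sensitive to this change, even though the counts of hydrogen-bond donors and acceptors stay the same and neither group carries a net charge. No measurement is available that explains the size of this step.

The compounds shown leave open whether the step follows the nitrogen or the ethyl group, which a simple amino group, methylamino or methoxy in the same place could separate. They also leave open whether ethylamino brings a similar step on the cores of compound 2 and compound 3.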